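Benzyl-ether variants of a fluorinated bicyclic amino acid core

A few compounds are considered here, and "the series" means these few. Any claim that something is new, unique, unknown or untested is made for them only; others in the source may bear on it.

Compound 1 `CCC(C)O[C@@H]1C[C@@H]2[C@H]([C@]1(N)C(=O)O)[C@@]2(F)C(=O)O` carries a sec-butyl ether on the shared core, and in an assay on CHO cells for binding affinity to metabotropic glutamate receptor 2 (Rattus norvegicus) (a lower number here means a stronger inhibitor, a higher number a weaker inhibitor), compound 1 gives 6.68 nM. Compound 2 `N[C@]1(C(=O)O)[C@H]2[C@@H](C[C@H]1OCc1ccccc1)[C@]2(F)C(=O)O` carries a benzyl ether on the same oxygen; in this assay compound 2 gives 7.14 nM, and the step of a 1.1-fold higher number from compound 1 to compound 2 (0.03 log units; within the scatter) lies within the scatter. Compound 3 `N[C@]1(C(=O)O)[C@H]2[C@@H](C[C@H]1OCc1ccc(-c3ccccc3)cc1)[C@]2(F)C(=O)O` adds a phenyl to the benzyl ring; in this assay compound 3 gives 25.6 nM, and the step of a 3.6-fold higher number from compound 2 to compound 3 (0.55 log units; beyond the scatter) is a modest weakening. Among the three numbers compound 2 sits with compound 1 within the scatter and differs beyond it only from compound 3.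

Compound 4 `N[C@]1(C(=O)O)[C@H]2[C@@H](C[C@H]1OCc1cccc(Oc3ccccc3)c1)[C@]2(F)C(=O)O` differs from compound 2 by phenoxy in place of hydrogen on an aromatic carbon. Within the data shown here, the one measured step that bears on enlarging the benzyl ring with an aromatic group is a 3.6-fold higher number from compound 2 to compound 3 (0.55 log units; beyond the scatter), and that group entered at a different place and without an oxygen link; no measured step covers the place meta to a large group. A step in the same direction, somewhat smaller, is therefore expected in this assay: a 2.5-fold higher number from compound 2 to compound 4 (0.40 log units; beyond the scatter). On this basis compound 4 is expected to give about 18 nM in this assay, with a range from 7 nM to 45 nM.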

Compound 4, inhibition constant: 7.15 nM
For compound 4 the middle estimate is 2.5-fold (0.40 log units) above the measured one; the range from low to high includes it.
By their numbers in this assay, from the lowest: compounds 1, 2 and 4 (each within the scatter of the next); then compound 3.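

With phenoxy in place of hydrogen on an aromatic carbon, meta to a large group, the step in this assay is a 1.0-fold higher number from compound 2 to compound 4 (0.00 log units; within the scatter). Enlarging the benzyl ring of compound 2 with a further aromatic ring therefore does not in itself carry a step beyond the scatter: the phenyl of compound 3 does, with a 3.6-fold higher number from compound 2 to compound 3 (0.55 log units; beyond the scatter), while the phenoxy of compound 4 does not, so the two enlargements part ways and no single rule for large groups on this ring covers both. Nothing at hand accounts for that difference between the two steps.

Still open, as far as these compounds go, is whether this place accepts groups other than phenoxy, such as an amine, a carboxylic acid or a longer chain joined through the same oxygen. Also open, from the compounds shown here alone, is how much of the difference belongs to the place on the ring and how much to the oxygen link, which would take phenyl at the place held by phenoxy in compound 4 and phenoxy at the place held by phenyl in compound 3 to separate.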